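A Nitro-Bearing Aryl Swap on a Shared Core

A few compounds are considered here, and "the series" means these few. Any claim that something is new, unique, unknown or untested is made for them only; others in the source may bear on it.

Values in a functional assay for inhibition, with Homo sapiens as the target; a higher number here means weaker binding, a lower number tighter binding:
- compound 1 `COc1ccc(OC(C)(C)C2OCC(C/C=C\CCC(=O)O)C(c3cccnc3)O2)cc1`: 302 nM
- compound 2 `CC(C)(Oc1ccccc1F)C1OCC(C/C=C\CCC(=O)O)C(c2cccnc2)O1`: 166 nM
- compound 3 `CC(C)(Oc1ccccc1O)C1OCC(C/C=C\CCC(=O)O)C(c2cccnc2)O1`: 95.5 nM

For the measured compounds named here, only one gap around compound 3 is clear. a 3.2-fold lower number from compound 1 to compound 3 (0.50 log units; beyond the scatter) lies beyond the usual scatter of repeat measurements, while a 1.7-fold lower number from compound 2 to compound 3 (0.24 log units; within the scatter) lies within it.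

The next change gives compound 4 `CC(C)(Oc1ccc(F)cc1[N+](=O)[O-])C1OCC(C/C=C\CCC(=O)O)C(c2cccnc2)O1`, with 4-fluoro-2-nitrophenyl in place of 2-hydroxyphenyl on an oxygen on a saturated carbon. The measured swaps at this same place are the guide. a 1.8-fold lower number from compound 1 to compound 2 (0.26 log units; within the scatter) stays within the scatter, and the largest, a 3.2-fold lower number from compound 1 to compound 3 (0.50 log units; beyond the scatter), is modest. Going by the values given here, no measured compound carries a nitro group, so these steps give only a rough guide. In this assay, the expected step is small and slightly upward, a 1.4-fold higher number from compound 3 to compound 4 (0.13 log units; within the scatter), and not beyond the scatter. Compound 4 is estimated at 130 nM, with an expected range of 45 nM to 380 nM.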

Compound 4, dissociation constant: 2.51 nM
For compound 4 the middle estimate is 52-fold (1.71 log units) above the measured one; measured number below the stated range.
By their numbers in this assay, from the lowest: compound 4; then compounds 3, 2 and 1 (each within the scatter of the next, the first and the last beyond it).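

In this assay, the earlier swaps on this oxygen moved the number only modestly, the largest being (a 3.2-fold lower number from compound 1 to compound 3 (0.50 log units; beyond the scatter)), so the aryl group here seemed to matter little. The 4-fluoro-2-nitrophenyl group changes that picture, with large steps from each earlier compound (a 38-fold lower number from compound 3 to compound 4 (1.58 log units; beyond the scatter); a 66-fold lower number from compound 2 to compound 4 (1.82 log units; beyond the scatter); a 120-fold lower number from compound 1 to compound 4 (2.08 log units; beyond the scatter)), which shows that this one position can shift the number much further than the first three compounds suggested and leaves compound 4 with the lowest number of the four. No separate measurement bears on why the number falls so far.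

As far as these compounds go, compound 4 brings in the nitro group and the fluoro group together, so it remains open whether one of them alone carries the step. From the compounds shown here alone, it is also open whether a nitrile or an amine in place of the nitro group would give a similar number.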